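Compound 4 Changes the Benzyl Group, Not the Chain

The compounds below may be only part of what the source reports. "The series", "measured", "known", "first", "only" and "open" are said of these compounds alone.

Compound 1 `CCCCOC(=O)/C=C/c1ccc2c(c1)C(=O)C(=O)N2Cc1ccc(OC)cc1` is measured in a functional assay on HT-29 cells (Homo sapiens) for cytotoxicity, read by MTT assay, with a stated time of 48 h (a higher number here means a weaker inhibitor, a lower number a stronger inhibitor), where compound 1 gives 420 nM. Of the three numbers measured, compound 1 sits close to compound 2 and well away from compound 3. Compound 2 `COc1ccc(CN2C(=O)C(=O)c3cc(/C=C/C(=O)OCCO)ccc32)cc1` gives 550 nM, and the step of a 1.3-fold higher number from compound 1 to compound 2 (0.12 log units; within the scatter) stays within the scatter. Compound 3 `COC(=O)/C=C/c1ccc2c(c1)C(=O)C(=O)N2Cc1ccc(OC)cc1` gives 30 nM; the step of a 14-fold lower number from compound 1 to compound 3 (1.15 log units; beyond the scatter) is large, as is an 18-fold lower number from compound 2 to compound 3 (1.26 log units; beyond the scatter). All three steps alter the chain on the oxygen next to a carbonyl group. Compound 4 `CCCCOC(=O)/C=C/c1ccc2c(c1)C(=O)C(=O)N2Cc1ccc(Br)cc1` differs from compound 1 elsewhere: bromo in place of methoxy on an aromatic carbon. Going by the values given here, no measured step touches the 4-methoxybenzyl, so none bears directly on this change, and no step beyond the scatter is expected in this assay. Compound 4 is therefore estimated at 420 nM, within 120 nM to 1500 nM, meaning an expected step of no change at the digits printed from compound 1 to compound 4 (within the scatter).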

Compound 4, half-maximal inhibitory concentration: 600 nM
Compound 4: the middle estimate sits 1.4-fold (0.15 log units) below what was measured; the measured number falls inside the stated range.
By their numbers in this assay, from the lowest: compound 3; then compounds 1, 2 and 4 (each within the scatter of the next).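

In this assay, the first change shown on the benzyl group gives a 1.4-fold higher number from compound 1 to compound 4 (0.15 log units; within the scatter) and so leaves the reading unmoved beyond the scatter. Methoxy, with its hydrogen-bond acceptor, can therefore give way to bromo, which has none, at this aromatic carbon, at least with the ester chain of compound 1. Nothing available explains why the two groups read alike here.

Going by these compounds, it remains open whether the same change would read alike on compound 3, with its much lower number. On these data alone, how an amine or a carboxylic acid would fare on this carbon also remains open.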